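Methoxy to benzyloxy: extending compound 2

The compounds below may be only part of what the source reports. "The series", "measured", "known", "first", "only" and "open" are said of these compounds alone.

Among the compounds with values here, in a functional assay on SK-OV-3 cells (Homo sapiens) for inhibition, read by CCK-8 assay, with a stated time of 70 h (a higher number here means a weaker inhibitor, a lower number a stronger inhibitor), compound 2 `COc1ccc(COc2ccc(OCCOCCNC3CCCC3)cc2)cc1` gives 15700 nM, the only true number among the measured compounds. Compound 1 `O=C(O)c1cccc(COc2ccc(OCCOCCNC3CCCC3)cc2)c1` gives > 100000 nM, which is a limit of the assay and not a number. Compound 3 `O=C(O)c1ccccc1COc1ccc(OCCOCCNC2CCCC2)cc1` gives > 100000 nM, which is the same limit.

The next compound is compound 4 `c1ccc(COc2ccc(COc3ccc(OCCOCCNC4CCCC4)cc3)cc2)cc1`. Its change from compound 2 is phenyl in place of hydrogen on a saturated chain carbon bound to an oxygen on an aromatic ring. Cut one bond further out, the same change reads methoxy to benzyloxy.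

Within the data shown here, two measured steps bear on this place in the molecule. One is an at least 6.3-fold lower number from compound 1 to compound 2 (0.80 log units; beyond the scatter), and the other is an at least 6.3-fold higher number from compound 2 to compound 3 (0.80 log units; beyond the scatter). On these data alone, both lie beyond the scatter, but each rests on a limit, so their true sizes remain open. Both steps exchange 4-methoxyphenyl for a carboxyphenyl group, and compound 4 carries no carboxyphenyl group. Neither step tests an added phenyl, so they offer only weak guidance here.

The likeliest outcome is therefore a small move towards a lower number, with no clear change beyond the scatter. The expected step is a 1.7-fold lower number from compound 2 to compound 4 (0.24 log units; within the scatter). For compound 4 the estimated value is 9000 nM, with an expected range from 2500 nM to 30000 nM.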

Compound 4, half-maximal inhibitory concentration: 10000 nM
The estimate for compound 4 lay 1.1-fold (0.05 log units) below the measured number; the range from low to high includes it.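

In this assay, phenyl in place of hydrogen on the saturated chain carbon bound to an oxygen on an aromatic ring gives a 1.6-fold lower number from compound 2 to compound 4 (0.20 log units; within the scatter), so this change does not separate the two compounds. The earlier steps shown here exchanged 4-methoxyphenyl for a carboxyphenyl group and said nothing about a larger group without a carboxylic acid. This step shows that the place accepts the six extra heavy atoms of a phenyl ring, as benzyloxy in place of methoxy, with no change beyond the scatter. For compound 1 and compound 3 the read-out is a limit and not a number: the limit of > 100000 nM in this assay, at which 2 of the 4 values shown sit.

Still open, on these data alone, is whether any group at this place can bring a step to a lower number beyond the scatter, which a longer chain such as phenylethoxy, or a nitrile on the added phenyl, would test. Also open, as far as these compounds go, is how far compound 1 and compound 3 truly lie from compound 2, and the step from compound 1 to compound 3 cannot be read.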